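Tetrazole in place of carboxy on the aromatic carbon

The source may hold more compounds than are shown below. What is called first, only, known or untested is meant among the compounds shown, and "the series" means these compounds.

Compound 1 `N#Cc1ccc(Nc2cc3[nH]c(-c4cccc(C(F)(F)F)c4)nc3cn2)nc1` and compound 2 `O=C(O)c1ccc(Nc2cc3[nH]c(-c4cccc(C(F)(F)F)c4)nc3cn2)nc1` share one core and differ only in the group on an aromatic carbon, carboxy in place of cyano. In a physicochemical assay for solubility, using the shake flask method, measured as kinetic solubility, with a stated time of 20 h, at pH 2 (a higher number here means a more soluble compound, a lower number a less soluble compound), compound 1 gives < 5000 nM, which is a limit of the assay and not a number. In this assay compound 2 gives < 5000 nM, again a limit of the assay. The step that the two limits leave unreadable from compound 1 to compound 2 is therefore unreadable, as both values sit at the limit of < 5000 nM in this assay, at which 2 of the 2 values shown sit. Compound 3 `FC(F)(F)c1cccc(-c2nc3cnc(Nc4ccc(-c5nnn[nH]5)cn4)cc3[nH]2)c1` carries the change (1H-tetrazol-5-yl in place of carboxy on an aromatic carbon). No measured step in the series bears on this exchange, since the one step shown is hidden by the limit, and compound 2 stands only at that limit. Compound 3 is therefore expected to remain at the limit, with the expected step that the limit leaves unreadable from compound 2 to compound 3 not readable beyond the scatter. For compound 3 the estimate in this assay is 3000 nM, within a range from 800 nM to 9000 nM.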

Compound 3, solubility: < 5000 nM
Compound 3: no number, only a limit; the forecaster's own chance of this, stated with the estimate: 70%; the middle value lies beyond the limit too.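

In this assay compound 3 gives < 5000 nM, a limit of the assay and not a number. No step among compound 1, compound 2 and compound 3 can be read: the limit of < 5000 nM in this assay, at which 3 of the 3 values shown sit.

The compounds shown leave open whether cyano, carboxy and 1H-tetrazol-5-yl differ at all in solubility.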